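Replacing 4-bromophenyl with 2-hydroxyethyl on the shared core

The compounds below may be only part of what the source reports. "The series", "measured", "known", "first", "only" and "open" are said of these compounds alone.

Measured compounds:
compound 1 `CN(CCNCc1cn(-c2ccc(F)cc2)nn1)CCNc1ccnc2cc(Cl)ccc12`: 19000 nM
compound 2 `CN(CCNCc1cn(-c2ccccc2Cl)nn1)CCNc1ccnc2cc(Cl)ccc12`: 12000 nM
compound 3 `CN(CCNCc1cn(Cc2ccc(Br)cc2)nn1)CCNc1ccnc2cc(Cl)ccc12`: 9300 nM

In a functional assay on HCC827 cells (Homo sapiens) for antiproliferative activity, read by sulforhodamine B assay, with a stated time of 72 h (a lower number here means a stronger inhibitor, a higher number a weaker inhibitor), compound 3 gives 9300 nM, the smallest of the three numbers. The gap to compound 2 is within the scatter (a 1.3-fold lower number from compound 2 to compound 3 (0.11 log units; within the scatter)), while the gap to compound 1 is beyond it, though modest (a 2.0-fold lower number from compound 1 to compound 3 (0.31 log units; beyond the scatter)). The remaining measured step, a 1.6-fold lower number from compound 1 to compound 2 (0.20 log units; within the scatter), is within the scatter.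

Compound 4 `CN(CCNCc1cn(CCCO)nn1)CCNc1ccnc2cc(Cl)ccc12` differs from compound 3 by 2-hydroxyethyl in place of 4-bromophenyl on a saturated chain carbon bound to an aromatic nitrogen. Going by the values given here, none of the measured steps bears directly on this change: all three measured compounds keep a six-membered aromatic ring of carbon at this position and differ only in its halogen or in the linking carbon, and those steps span a narrow band. Among the compounds with values here, compound 4 removes that ring altogether, so the expectation rests on no measured precedent. The expected outcome for compound 4 is a higher number than compound 3, of moderate size, a 2.7-fold higher number from compound 3 to compound 4 (0.43 log units; beyond the scatter), with wide uncertainty. Compound 4 is therefore estimated at 25000 nM, with a range from 8000 nM to 80000 nM.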

Compound 4, half-maximal inhibitory concentration: > 200000 nM
Compound 4 gave a limit, no number; the forecaster's own chance of this, stated with the estimate: 20%; middle value at least 8.0-fold (0.90 log units) away from the limit.
By their numbers in this assay, from the lowest: compounds 3, 2 and 1 (each within the scatter of the next, the first and the last beyond it). At a limit, above all of these: compound 4.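

In this assay compound 4 gives > 200000 nM, which is a limit and not a number. The steps to it are an at least 21-fold higher number from compound 3 to compound 4 (1.33 log units; beyond the scatter), an at least 16-fold higher number from compound 2 to compound 4 (1.22 log units; beyond the scatter) and an at least 10-fold higher number from compound 1 to compound 4 (1.02 log units; beyond the scatter), each large, whereas the changes of halogen or linking carbon among the three earlier compounds stay in a narrow band. The earlier compounds shown here therefore showed only that this position accepts several halogenated aromatic groups, while 3-hydroxypropyl in place of 4-bromobenzyl, which removes the six-membered aromatic ring and brings in a hydrogen-bond donor, shows that the series does not keep its number once that ring is gone.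

The compounds shown cannot tell whether the loss of the ring or the arrival of the hydroxyl carries this step. From the compounds shown here alone, a plain propyl chain in place of 3-hydroxypropyl would separate the two, and an amine or a carboxylic acid there remains open as well.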